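Swapping Phenyl for Ethoxy on the Dichloro Core

The source may hold more compounds than are shown below. What is called first, only, known or untested is meant among the compounds shown, and "the series" means these compounds.

Of the compounds shown here, three have so far been tested in a functional assay on Caco-2 cells (Homo sapiens) for inhibition, read by sulforhodamine B assay, with a stated time of 48 h; a lower number here means a stronger inhibitor, a higher number a weaker inhibitor. Compound 1 `O=c1c([C@@H]2C[C@H](c3ccccc3)ON2c2ccccc2)coc2cc(Cl)c(Cl)cc12` gives 23500 nM, the lower of the two measured numbers. Compound 3 `O=c1c([C@@H]2C[C@H](c3ccccc3)ON2c2ccccc2)coc2ccc(F)cc12` gives 60000 nM. Compound 2 `CCO[C@H]1C[C@@H](c2coc3ccc(F)cc3c2=O)N(c2ccccc2)O1` reaches only a limit of the assay, > 60000 nM, and not a number. How the core of compound 1 differs from the core of compound 3 is not broken down here.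

One structural change appears within the series, from compound 3 to compound 2: ethoxy in place of phenyl on a saturated ring carbon The step this change made is a number no lower from compound 3 to compound 2 (the limit leaves the size open), and its size cannot be read because of the limit of > 60000 nM in this assay, at which 1 of the 3 values shown sits.

Compound 4 `CCO[C@H]1C[C@@H](c2coc3cc(Cl)c(Cl)cc3c2=O)N(c2ccccc2)O1` has not yet been measured. Relative to compound 1 it carries the same change, at the same place in the ring: ethoxy in place of phenyl on a saturated ring carbon Resting on the measured step of a number no lower from compound 3 to compound 2 (the limit leaves the size open), which gave no lower a number after the change, the step from compound 1 to compound 4 is expected to be a 2.6-fold higher number from compound 1 to compound 4 (0.41 log units; beyond the scatter). In this assay compound 4 is therefore estimated at 60000 nM, with a likely range from 20000 nM to 200000 nM.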

Compound 4, half-maximal inhibitory concentration: > 60000 nM
Compound 4 was reported as a limit; the forecaster's own chance of this, stated with the estimate: 50%; the middle value lies on the limit itself.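

In this assay, putting ethoxy in place of phenyl on the core of compound 1 gives an at least 2.5-fold higher number from compound 1 to compound 4 (0.40 log units; beyond the scatter), so on this core the change leaves a clearly weaker inhibitor. The same swap on the core of compound 3 also gave no lower a number, so neither of the two cores shown gains from the change, and in that sense its direction carries over: the same change on two cores in this assay, a number no lower (the limit leaves the size open) from compound 3 to compound 2 and an at least 2.5-fold higher number (0.40 log units; beyond the scatter) from compound 1 to compound 4; the limit leaves it open whether they differ The true size of the step on the core of compound 3 cannot be read, and it stays unknown whether the change costs more on one core than on the other, because compound 2 and compound 4 are both reported only as a limit: the limit of > 60000 nM in this assay, at which 2 of the 4 values shown sit.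

The compounds shown leave open whether another group in place of phenyl on this saturated ring carbon, such as an amine, a methoxy or a longer chain, would keep more of the inhibition. They also leave open how the swap would behave on any third core.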